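The source may hold more compounds than are shown below. What is called first, only, known or untested is meant among the compounds shown, and "the series" means these compounds.

Working notes on the series. Compound 1 `Nc1ccccc1NC(=O)CCCNCC(=O)Nc1cc(Cl)ccc1Cl` is the starting point here. In a functional assay on U-251 cells (Homo sapiens) for inhibition, read by MTT assay, with a stated time of 2 days (a higher number here means a weaker inhibitor of growth, a lower number a stronger inhibitor of growth), compound 1 gives > 100000 nM, which is a limit of the assay and not a number (the limit of > 100000 nM in this assay, at which 1 of the 3 values shown sits). Two analogues on another core are measured: compound 2 `Nc1ccccc1NC(=O)c1ccc(NCC(=O)Nc2ccc([N+](=O)[O-])cc2)cc1` gives 42500 nM in this assay, and compound 3 `Nc1ccccc1NC(=O)c1ccc(NCC(=O)Nc2ccc(Cl)cc2)cc1` gives 62500 nM. Among the compounds with values here, the single one-place step, a 1.5-fold higher number from compound 2 to compound 3 (0.17 log units; within the scatter), stays within the scatter. Compound 4 `Nc1ccccc1NC(=O)CCCNCC(=O)Nc1ccc(Cl)cc1` differs from compound 1 as follows: 4-chlorophenyl in place of 2,5-dichlorophenyl on an amide-type nitrogen. The measured step concerns another substituent on another core, so it bears only loosely, and no step beyond the scatter is expected. Compound 4 is expected to give 100000 nM, between 40000 nM and 250000 nM. For compound 4 the expected step is therefore a number no higher from compound 1 to compound 4 (the limit leaves the size open), with a further limit likely.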

Compound 4, concentration for total growth inhibition: 75000 nM
The estimate for compound 4 lay 1.3-fold (0.12 log units) above the measured number; the measured number falls inside the stated range.
By their numbers in this assay, from the lowest: compounds 2, 3 and 4 (each within the scatter of the next). At a limit, above all of these: compound 1.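

The shared core now carries a number and not only a limit: in this assay, 4-chlorophenyl in place of 2,5-dichlorophenyl on the amide-type nitrogen gives an at least 1.3-fold lower number from compound 1 to compound 4 (0.12 log units; that floor lies within the scatter). From the compounds shown here alone, the value of compound 1 is a limit of the assay and not a number: the limit of > 100000 nM in this assay, at which 1 of the 4 values shown sits. The floor of the step therefore does not separate the two groups, and its true size stays open.

Open, going by these compounds, is whether an unsubstituted phenyl, a methoxyphenyl or a longer chain would move the number beyond the scatter. Nothing shown ties the step to either chlorine alone.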